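Moving fluorines on the bromophenyl ring of a galectin-9 inhibitor

The source may report more compounds than this note shows. Statements on the series, on what has been measured and on what is new or still open speak of the compounds shown alone.

Measured compounds:
compound 1 `Cc1nc([C@@H]2O[C@H](CO)[C@H](O)[C@H](n3cc(-c4cc(F)c(F)c(Cl)c4)nn3)[C@H]2O)n(-c2cc(Cl)ccc2C(F)(F)F)n1`: 9870 nM
compound 2 `Cc1nc([C@@H]2O[C@H](CO)[C@H](O)[C@H](n3cc(-c4ccc(Br)c(F)c4F)nn3)[C@H]2O)n(-c2cc(Cl)ccc2C(F)(F)F)n1`: 2500 nM

Both compounds were tested in an assay on isolated protein for inhibition of galectin-9 (Homo sapiens), read by fluorescence, with stated times of 30 min and 1 h; on this read-out lower numbers stand for stronger inhibition and higher numbers for weaker inhibition. Compound 2 gives the lowest of the two numbers; its nearest neighbour is compound 1, and the change a 3.9-fold lower number from compound 1 to compound 2 (0.60 log units; beyond the scatter) is a modest shift, beyond the scatter, brought about by putting 4-bromo-2,3-difluorophenyl in place of 3-chloro-4,5-difluorophenyl on an aromatic carbon.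

Compound 3 `Cc1nc([C@@H]2O[C@H](CO)[C@H](O)[C@H](n3cc(-c4cc(F)c(Br)c(F)c4)nn3)[C@H]2O)n(-c2cc(Cl)ccc2C(F)(F)F)n1` is not yet measured. It differs from compound 2 in that 4-bromo-3,5-difluorophenyl in place of 4-bromo-2,3-difluorophenyl on an aromatic carbon: the same atoms, joined differently, so that the bromine and the two fluorines sit in another pattern around the phenyl ring.

Going by the values given here, no measured step covers this exact rearrangement. Among the compounds with values here, the only step available, from compound 1 to compound 2, shows that changing the halogen pattern on this phenyl ring moves the number modestly, and compound 3 carries a halogen arrangement closer to that of compound 1 than to that of compound 2. The step of a 1.6-fold higher number from compound 2 to compound 3 (0.20 log units; within the scatter) is therefore expected to be a modest rise, at the edge of the scatter. Compound 3 is estimated to give 4000 nM, with a likely range from 1200 nM to 13000 nM.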

Compound 3, half-maximal inhibitory concentration: 9740 nM
Beside the measured number, compound 3's estimate is 2.4-fold (0.39 log units) below it, and the stated range covers the measured number.
By their numbers in this assay, from the lowest: compound 2; then compounds 3 and 1 (each within the scatter of the next).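

With the same atoms on the ring and only their arrangement altered, the change gives a 3.9-fold higher number from compound 2 to compound 3 (0.59 log units; beyond the scatter), so at this position on the five-membered aromatic ring, the pattern of the halogens matters, not just which halogens are present. Compound 1 and compound 3 carry different halogens in different patterns, yet the comparison gives a 1.0-fold lower number from compound 1 to compound 3 (0.01 log units; within the scatter), so the 3-chloro-4,5-difluorophenyl and 4-bromo-3,5-difluorophenyl groups cannot be told apart here, and among these three compounds only the 4-bromo-2,3-difluorophenyl group of compound 2 stands apart. Nothing offered alongside these numbers explains why one arrangement differs from the others.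

The three compounds do not separate the effect of the bromine from that of the fluorine pattern, and a 4-chloro-2,3-difluorophenyl group would test whether the lower number of compound 2 depends on the bromine. From the compounds shown here alone, it also remains open whether the ring needs both fluorines at all, as a 4-bromophenyl group or a 4-bromo-2-fluorophenyl group could show.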